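A Fluorinated Side Chain Reshaped on a Carbamate Oxygen

A few compounds are considered here, and "the series" means these few. Any claim that something is new, unique, unknown or untested is made for them only; others in the source may bear on it.

Three compounds share one core and differ only in the group on an oxygen next to a carbonyl group. Compound 1 `Cc1nc(S(C)(=O)=O)ccc1Oc1ncnc(OC2CCN(C(=O)OC3CCC3)CC2)c1F` carries cyclobutyl there, and in a functional assay on isolated protein for inhibition of Glucose-dependent insulinotropic receptor (Rattus norvegicus), read by HTRF and cAMP accumulation (on this read-out lower numbers stand for smaller maximal responses and higher numbers for larger maximal responses), compound 1 reaches 81%. Compound 2 `Cc1nc(S(C)(=O)=O)ccc1Oc1ncnc(OC2CCN(C(=O)OC(C)(C)C(F)(F)F)CC2)c1F` carries 1-methyl-1-(trifluoromethyl)ethyl, and in this assay compound 2 reaches 79%; the step of a number 2 percentage points lower from compound 1 to compound 2 (within the scatter) stays within the scatter. Compound 3 `Cc1nc(S(C)(=O)=O)ccc1Oc1ncnc(OC2CCN(C(=O)OC(C)F)CC2)c1F` carries 1-fluoroethyl, and in this assay compound 3 reaches 68%, the lowest of the three numbers: the steps of a number 13 percentage points lower from compound 1 to compound 3 (beyond the scatter) and a number 11 percentage points lower from compound 2 to compound 3 (beyond the scatter) both lie beyond the scatter.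

Compound 4 `Cc1nc(S(C)(=O)=O)ccc1Oc1ncnc(OC2CCN(C(=O)O[C@H](C)CF)CC2)c1F` has not yet been measured. It differs from compound 3 as follows: 1-(fluoromethyl)ethyl in place of 1-fluoroethyl on an oxygen next to a carbonyl group.

The two steps that bear on this change are the two leading to compound 3, each a modest drop when 1-fluoroethyl replaced a group with more heavy atoms. Compound 4 adds one carbon to the group of compound 3, yet its group still counts fewer heavy atoms than those of compound 1 or compound 2. Compound 4 is therefore expected to show a step of a number 5 percentage points higher from compound 3 to compound 4 (within the scatter), small enough to stay within the scatter. Compound 4 is estimated to reach 73% in this assay, with a range from 62% to 84%.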

Compound 4, largest response reached (reported as efficacy), in percent of the reference or control that the assay uses: 79%
Beside the measured number, compound 4's estimate is 6 percentage points below it; low and high end bracket the measured number.
By their numbers in this assay, from the lowest: compound 3; then compounds 2, 4 and 1 (each within the scatter of the next).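

In this assay the step to the group with 4 heavy atoms gives a number 11 percentage points higher from compound 3 to compound 4 (beyond the scatter) and shows that the lower number of compound 3 does not extend to every small fluorinated chain on this oxygen. The comparisons with the other two groups read no change at the digits printed from compound 2 to compound 4 (within the scatter) and a number 2 percentage points lower from compound 1 to compound 4 (within the scatter) and place 1-(fluoromethyl)ethyl level with 1-methyl-1-(trifluoromethyl)ethyl and cyclobutyl, even though it has fewer heavy atoms than either. Among these four compounds, then, 1-fluoroethyl alone stands apart, and heavy-atom count does not by itself sort the numbers, since compound 4 sits with the groups that have more heavy atoms while differing from compound 3 by a single carbon.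

The compounds shown leave open how the mirror-image form of the 1-(fluoromethyl)ethyl group would compare at its defined stereocentre, and whether the fluorine matters at all, a question that the plain isopropyl group or a longer chain such as 3-fluoropropyl would address. Nothing available here explains why the two closely related fluorinated groups give different numbers.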